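The compounds below may be only part of what the source reports. "The series", "measured", "known", "first", "only" and "open" are said of these compounds alone.

Compound 1 `O=C(/C=C\c1ccccc1O)N1N=C(c2ccncc2)OC1c1c[nH]c2ccccc12` was tested in an ADME assay on PANC-1 cells (Homo sapiens) for cytotoxicity, read by MTT assay, with a stated time of 48 h (on this read-out lower numbers stand for stronger inhibition of growth and higher numbers for weaker inhibition of growth), where compound 1 gives only a limit, > 30 ug/mL. Compound 2 `O=C(/C=C\c1ccccc1Cl)N1N=C(c2ccncc2)OC1c1c[nH]c2ccccc12` in this assay likewise gives only a limit, > 30 ug/mL. The step that the two limits leave unreadable from compound 1 to compound 2, chloro in place of hydroxy on an aromatic carbon, cannot be read because of the limit of > 30 ug/mL in this assay, at which 2 of the 2 values shown sit. Compound 3 `O=C(/C=C\c1ccc(Cl)cc1)N1N=C(c2ccncc2)OC1c1c[nH]c2ccccc12` has not yet been measured. It differs from compound 2 by 4-chlorophenyl in place of 2-chlorophenyl on a double-bonded chain carbon bound to a double-bonded chain carbon. No readable measured step bears on this change, so no direction can be drawn from the data. With both values sitting at the limit, the plain expectation is that compound 3 stays in the same region, and compound 3 is estimated at 40 ug/mL, between 20 ug/mL and 100 ug/mL. That estimate means a step that the limit leaves unreadable from compound 2 to compound 3 expected to lie within the scatter.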

Compound 3, concentration for 50% growth inhibition: > 30 ug/mL
Compound 3 gave a limit, no number; the forecaster's own chance of this, stated with the estimate: 75%; the middle value is on the limit's open side.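

No step can be read among compound 1, compound 2 and compound 3, because all three stop at the same limit: the limit of > 30 ug/mL in this assay, at which 3 of the 3 values shown sit. The compounds shown leave open how strongly each inhibits growth in this assay, and whether 4-chlorophenyl in place of 2-chlorophenyl makes any difference.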